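From Compound 2 to Compound 3: An Aryl Amine Exchange

A few compounds are considered here, and "the series" means these few. Any claim that something is new, unique, unknown or untested is made for them only; others in the source may bear on it.

Compound 1 `O=C(CSc1nc(Nc2ccccc2)c2ccccc2n1)Nc1cccc(Cl)c1` — 14300 nM
Compound 2 `C=CC(=O)Nc1cccc(NC(=O)CSc2nc(Nc3ccccc3C)c3ccccc3n2)c1` — 30200 nM

Of the compounds shown here, two have been measured in a functional assay on MGC-803 cells (Homo sapiens) for inhibition, read by MTT assay, with a stated time of 72 h; on this read-out higher numbers stand for weaker inhibition and lower numbers for stronger inhibition. Compound 1 gives 14300 nM, and compound 2 gives 30200 nM, the higher of the two numbers; the gap between them lies beyond the usual scatter, so compound 2 is the weaker of the pair on this read-out. The two share a core but differ in several places at once, so no single change can be read from their values.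

Compound 3 `C=CC(=O)Nc1cccc(NC(=O)CSc2nc(Nc3ccc(C(F)(F)F)cc3)c3ccccc3n2)c1` differs from compound 2 in one place: 4-(trifluoromethyl)phenyl in place of 2-methylphenyl on a nitrogen on an aromatic ring. For the measured compounds named here, no measured pair isolates this change, and the only comparison available, compound 1 against compound 2, involves more than one difference. The step from compound 2 to compound 3 is therefore expected to be small, without a clear direction, and likely within the scatter, as a 1.4-fold lower number from compound 2 to compound 3 (0.14 log units; within the scatter). Compound 3 is estimated at 22000 nM, with a range from 7000 nM to 70000 nM.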

Compound 3, half-maximal inhibitory concentration: 12100 nM
Compound 3: middle estimate off by 1.8-fold (0.26 log units), on the high side; low and high end bracket the measured number.
By their numbers in this assay, from the lowest: compounds 3 and 1 (each within the scatter of the next); then compound 2.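

In this assay, for the compounds shown here, the group on this nitrogen on an aromatic ring proves able to shift the number: 4-(trifluoromethyl)phenyl in place of 2-methylphenyl gives a 2.5-fold lower number from compound 2 to compound 3 (0.40 log units; beyond the scatter) and so provides the first single change that can be read here, though a modest one. The earlier pair could not show this, as compound 1 and compound 2 differ in more than one place. Nothing measured here accounts for the step.

The compounds shown leave open whether the same exchange would give a like step on the core of compound 1. They also leave open how a plain phenyl, or a phenyl carrying a methoxy group or an amine, would read on this nitrogen, and so whether the step belongs to the trifluoromethyl group or to the loss of the methyl group.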